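Acetyl on the hydroxyl of compound 2: an unreadable start

The source may hold more compounds than are shown below. What is called first, only, known or untested is meant among the compounds shown, and "the series" means these compounds.

The study measures inhibition in a functional assay on HeLa cells (Homo sapiens) for inhibition; on this read-out lower numbers stand for stronger inhibition and higher numbers for weaker inhibition. Compound 2, `CC(O)n1cnc2c(N)nc(I)nc21`, sits at a limit of that assay rather than at a number: in this assay compound 2 gives > 500000 nM. Compound 3, `Nc1nc(I)nc2c1ncn2OCCO`, also sits at a limit; in this assay compound 3 gives > 500000 nM. The step that the two limits leave unreadable from compound 2 to compound 3 therefore cannot be read, because both ends rest on (the limit of > 500000 nM in this assay, at which 2 of the 3 values shown sit). Among the measured compounds shown here, compound 1, `CC(=O)OC(C)n1cnc2c(Cl)nc(I)nc21`, is the only member with a number: in this assay compound 1 gives 5130 nM, but no single step joins it to compound 2 or to compound 4.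

Compound 4, `CC(=O)OC(C)n1cnc2c(N)nc(I)nc21`, differs from compound 2 by acetyl in place of hydrogen on an oxygen on a saturated carbon. For the measured compounds named here, since compound 2 stands at a limit, no measured step reaches it, and the only comparable step is unreadable. The author thus expects the step of an at least 1.6-fold lower number from compound 2 to compound 4 (0.22 log units; that floor lies within the scatter) to be undefined in direction, with a fair chance that compound 4 again reports a limit. For compound 4 in this assay the estimate is 300000 nM, in a range from 20000 nM to 500000 nM.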

Compound 4, half-maximal inhibitory concentration: > 500000 nM
Compound 4: a limit, no number (the forecaster's own chance of this, stated with the estimate: 60%); at least 1.6-fold (0.22 log units) between middle value and limit.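

In this assay, among the compounds shown here, amino in place of chloro on an aromatic carbon, with the acetoxy group kept, gives an at least 97-fold higher number from compound 1 to compound 4 (1.98 log units; beyond the scatter), the first step that can be read, and it places a large loss of inhibition at this aromatic carbon. Compound 4 gives > 500000 nM, which is a limit and not a number, so the size of this step is only a floor. The change from hydroxy to acetoxy on the saturated carbon cannot be read, and neither can the step from compound 2 to compound 3, because each of these steps has a limit at both ends: the limit of > 500000 nM in this assay, at which 3 of the 4 values shown sit.

Going by these compounds, it remains open whether the higher number belongs to the amino group as such or would also appear with another group on that aromatic carbon, such as methylamino or methoxy. On these data alone, it also remains open how hydroxy and acetoxy on the saturated carbon compare when chloro rather than amino sits on the aromatic carbon.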